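A few compounds are considered here, and "the series" means these few. Any claim that something is new, unique, unknown or untested is made for them only; others in the source may bear on it.

Values in a physicochemical assay for solubility, read by HPLC, in phosphate buffer, measured as kinetic solubility, at pH 7.4; a higher number here means a more soluble compound, a lower number a less soluble compound:
Compound 1 `CCOC(=O)c1cc(-c2ccc(F)cc2)n(-c2ccc(S(N)(=O)=O)cc2)c1C`: 12600 nM
Compound 2 `CCOC(=O)c1cc(-c2ccccc2Cl)n(-c2ccc(S(N)(=O)=O)cc2)c1C`: 13700 nM
Compound 3 `CCOC(=O)c1cc(-c2ccc(C)cc2)n(-c2ccc(S(N)(=O)=O)cc2)c1C`: 1300 nM

Compound 1 belongs to the high end of these three numbers. The gap to its nearest neighbour is a 1.1-fold higher number from compound 1 to compound 2 (0.04 log units; within the scatter), and the gap to its furthest is a 9.7-fold lower number from compound 1 to compound 3 (0.99 log units; beyond the scatter).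

Compound 4 `CCOC(=O)c1cc(-c2ccc(F)cc2)n(-c2ccc(S(N)(=O)=O)cc2)c1N` has not been measured yet. It differs from compound 1 in one place: amino in place of methyl on an aromatic carbon. This is amino in place of methyl on an aromatic carbon, next to the ring nitrogen and next to the ring atom that bears an ethoxycarbonyl group.

Among the measured compounds shown here, none of the measured steps touches that place. All of them alter the phenyl group that carries the fluoro, chloro or methyl, so they show only how far this assay can move on a single swap elsewhere. Such a swap can give a 1.1-fold higher number from compound 1 to compound 2 (0.04 log units; within the scatter), but also an 11-fold lower number from compound 2 to compound 3 (1.02 log units; beyond the scatter). With no direct evidence for a direction, the expectation is no step beyond the scatter, though a large move either way remains possible.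

The expected step is a 1.1-fold higher number from compound 1 to compound 4 (0.05 log units; within the scatter). For compound 4 the estimated value is 14000 nM, with an expected range of 3000 nM to 60000 nM.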

Compound 4, solubility: 7500 nM
Beside the measured number, compound 4's estimate is 1.9-fold (0.27 log units) above it; the measured number falls inside the stated range.
By their numbers in this assay, from the lowest: compound 3; then compounds 4, 1 and 2 (each within the scatter of the next).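

Among the compounds shown here, this is the first swap at the ring carbon next to the ring nitrogen and next to the ring atom that bears an ethoxycarbonyl group. In this assay, amino in place of methyl there gives a 1.7-fold lower number from compound 1 to compound 4 (0.23 log units; within the scatter), so a group with a hydrogen-bond donor and acceptor can replace one with neither without a step beyond the scatter, whereas a single swap on the phenyl group can give a 9.7-fold lower number from compound 1 to compound 3 (0.99 log units; beyond the scatter) in the same measurement. Nothing shown here explains why this step stays so small.

A single swap says little about the position as a whole, and the compounds shown leave open what a longer chain such as ethyl, a carboxylic acid or a dimethylamino group would do on this ring carbon. They also leave open whether amino in place of methyl would give a similarly small step in the 2-chlorophenyl compound 2 or the 4-methylphenyl compound 3, whose phenyl groups differ from that of compound 1.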